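Swapping the amide of compound 2 for a phenyl ketone

The source may hold more compounds than are shown below. What is called first, only, known or untested is meant among the compounds shown, and "the series" means these compounds.

Of the compounds shown here, two have been measured in a physicochemical assay for lipophilicity; a higher number here means a more lipophilic compound, a lower number a more polar compound. Compound 1 `CC#CCOC(=O)/C=C(C)/C=C/CC(C)CCCC(C)C` gives 6.4 in this assay, while compound 2 `CCNC(=O)/C=C(C)/C=C/CC(C)CCCC(C)C` gives 5.24. Among the compounds with values here, compound 2 thus holds the lower of the two numbers, with compound 1 standing beyond the scatter above it; the single measured step, a number 1.16 log units lower from compound 1 to compound 2 (beyond the scatter), corresponds to an ethylamino in place of a (but-2-yn-1-yl)oxy on the carbonyl carbon.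

Compound 3 `CC(/C=C/CC(C)CCCC(C)C)=C\C(=O)c1ccccc1` is not yet measured. It differs from compound 2 by phenyl in place of ethylamino on a carbonyl carbon; the carbonyl carbon that carries the change has a double-bonded chain carbon as its other neighbour. The step from compound 1 to compound 2 is the only one that bears on this change, and it was large. Reversing the direction of that step, the account expects compound 3 to move well beyond the scatter upward, by about a number 1.66 log units higher from compound 2 to compound 3 (beyond the scatter) in this assay. The estimate for compound 3 is therefore 6.9, with an expected range from 6.2 to 7.6.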

Compound 3, partition coefficient: 7.26
Compound 3: the middle estimate sits 0.36 log units below what was measured; low and high end bracket the measured number.
By their numbers in this assay, from the lowest: compound 2; then compound 1; then compound 3.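

With phenyl on the carbonyl carbon whose other neighbour is the double-bonded chain carbon, the read-out in this assay extends beyond the range set by the earlier pair, with a number 2.02 log units higher from compound 2 to compound 3 (beyond the scatter) and with a number 0.86 log units higher from compound 1 to compound 3 (beyond the scatter). The (but-2-yn-1-yl)oxy group therefore no longer marks the top of the series, and the three groups on this carbon now run from ethylamino through (but-2-yn-1-yl)oxy to phenyl, each separated from the next beyond the scatter. The change from ethylamino to phenyl removes one hydrogen-bond donor and brings in one six-membered aromatic ring of carbon only, but no measurement shown here explains the rise in this assay or assigns it to either difference.

The ring and the loss of the donor arrive together in this one step, so the compounds shown do not tell their contributions apart. An anilino group on the same carbonyl carbon, which keeps both a ring and a donor, and a cyclohexyl group, which carries a ring that is not aromatic, would each leave open a different part of that question.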